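Nitro in Place of Trifluoromethyl: What Compound 4 Should Show

This account rests on a few compounds, and the source may have more. Where it says the series, first, only, none or still open, it means among the compounds named here.

Compound 1 `FC(F)(F)c1ccc(COc2ccccc2Nc2ncnc3cc4c(cc23)OCCOCCO4)cc1` and compound 2 `FC(F)(F)c1ccc(COc2ccc(Nc3ncnc4cc5c(cc34)OCCOCCOCCOCCO5)cc2)cc1` are built on related cores, but the difference between the two cores is not broken down here. In a functional assay on SH-SY5Y cells (Homo sapiens) for antiproliferative activity, read by MTT assay, with a stated time of 72 h (on this read-out lower numbers stand for stronger inhibition and higher numbers for weaker inhibition), compound 1 gives > 100000 nM, which is a limit of the assay and not a number. Compound 2 gives 2140 nM in this assay. Compound 3 `O=[N+]([O-])c1ccc(COc2ccc(Nc3ncnc4cc5c(cc34)OCCOCCOCCOCCO5)cc2)cc1` differs from compound 2 by one change, (nitro in place of trifluoromethyl on an aromatic carbon). In this assay compound 3 gives > 100000 nM, again a limit and not a number. That change produced an at least 46-fold higher number from compound 2 to compound 3 (1.66 log units; beyond the scatter).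

Compound 4 `O=[N+]([O-])c1ccc(COc2ccccc2Nc2ncnc3cc4c(cc23)OCCOCCO4)cc1` carries the same change on the core of compound 1, (nitro in place of trifluoromethyl on an aromatic carbon), and the place is described in the same words for both pairs, so this is the same change. Since the earlier step weakened activity and compound 1 already sits at the limit, compound 4 is expected to show a step that the limit leaves unreadable from compound 1 to compound 4 in this assay, which can hardly register as a number because the limit of > 100000 nM in this assay, at which 2 of the 3 values shown sit, already holds compound 1. Compound 4 is therefore estimated at 200000 nM in this assay, most likely reported only as a limit, between 100000 nM and 600000 nM.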

Compound 4, half-maximal inhibitory concentration: > 100000 nM
Compound 4 was reported as a limit (the forecaster's own chance of this, stated with the estimate: 90%); the middle value is on the limit's open side.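

In this assay compound 1 and compound 4 are both reported only as limits, so no step can be read between them: the limit of > 100000 nM in this assay, at which 3 of the 4 values shown sit.

The compounds shown leave open whether nitro in place of trifluoromethyl changes activity at all on the core of compound 1, and by how much.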